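This account rests on a few compounds, and the source may have more. Where it says the series, first, only, none or still open, it means among the compounds named here.

Compound 1 `C/C=C/C(=O)N(Cc1ccc(OC)c([N+](=O)[O-])c1)c1cc(OC)c(OC)c(OC)c1` gives 670 nM
Compound 2 `COc1ccc(CN(C(C)=O)c2cc(OC)c(OC)c(OC)c2)cc1O` gives 270 nM
Compound 3 `COc1ccc(CNc2cc(OC)c(OC)c(OC)c2)cc1Br` gives 48100 nM

All three values come from a functional assay on HCT-116 cells (Homo sapiens) for inhibition, read by MTT assay, with a stated time of 48 h; a higher number here means a weaker inhibitor, a lower number a stronger inhibitor. Compound 2 has the lowest of the three numbers, which makes it the strongest inhibitor in this small set. Compound 1 lies nearest to it and compound 3 lies furthest away, and both gaps are beyond the scatter.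

The account now turns to compound 4 `CCC/C=C/C(=O)N(Cc1ccc(OC)c(O)c1)c1cc(OC)c(OC)c(OC)c1`, which has not yet been measured. It departs from compound 2 by a single change, with pent-1-en-1-yl in place of methyl on a carbonyl carbon. Among the compounds with values here, no pair of measured compounds isolates this change, so the data offer no direct guide to its effect. Within the data shown here, the closest available reference is compound 1 (670 nM), the only other measured compound with a number near that of compound 2 (270 nM). On that slender basis, a moderate weakening is expected in this assay rather than a collapse of the kind seen for compound 3 (48100 nM). The expected change is a 2.6-fold higher number from compound 2 to compound 4 (0.41 log units; beyond the scatter), an estimate that carries wide uncertainty. Compound 4 is estimated at 700 nM, with an expected range from 200 nM to 2500 nM.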

Compound 4, half-maximal inhibitory concentration: 95 nM
Beside the measured number, compound 4's estimate is 7.4-fold (0.87 log units) above it; the measured number lies below the stated range.
By their numbers in this assay, from the lowest: compound 4; then compound 2; then compound 1; then compound 3.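

In this assay, pent-1-en-1-yl in place of methyl on a carbonyl carbon gives a 2.8-fold lower number from compound 2 to compound 4 (0.45 log units; beyond the scatter), so the larger chain is not merely accepted at this position but comes with a modest gain. Within the data shown here, none of the earlier compounds could show this, since no measured pair isolated a change here, and this step, from acetyl to (pent-1-en-1-yl)carbonyl on the amide-type nitrogen, is the first direct reading: the group grows from 1 heavy atom to 5 and brings a double bond outside aromatic rings, and compound 4 now has the lowest number of the four. Nothing measured here accounts for the direction or the size of this step.

With a single chain shown at this position, it remains open whether the gain comes from the length of the chain or from its double bond, which a saturated pentyl chain would separate, and whether a longer chain or a phenyl group would extend or lose it. Going by these compounds, it is also open whether the gain would hold if a nitro group or a bromine took the place of the hydroxyl of compound 4.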